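Benzylsulfanyl sulfonylguanidines: chlorophenyl swap on compound 1

The compounds below may be only part of what the source reports. "The series", "measured", "known", "first", "only" and "open" are said of these compounds alone.

Measured compounds:
compound 1 `Cc1cccc(CSc2cc(Cl)c(C)cc2S(=O)(=O)/N=C(\N)n2nccc2-c2ccccc2)c1` gives 6500 nM in a functional assay on HCT-116 cells (Homo sapiens) for cytotoxicity, read by MTT assay, with a stated time of 72 h; on this read-out lower numbers stand for stronger inhibition and higher numbers for weaker inhibition
compound 2 `Cc1cccc(CSc2cc(Cl)c(C)cc2S(=O)(=O)/N=C(\N)n2nc(C)cc2-c2ccccc2)c1` gives 34000 nM in this assay
compound 3 `Cc1cc(-c2ccccc2)n(/C(N)=N/S(=O)(=O)c2cc(C)c(Cl)cc2SCc2ccc(Cl)cc2)n1` gives 7000 nM in this assay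

Compound 1 has the lowest number of the three in this assay, but compound 3 sits within the scatter of it, so no order between those two can be read. The step of a 5.2-fold higher number from compound 1 to compound 2 (0.72 log units; beyond the scatter) shows a methyl in place of hydrogen on an aromatic carbon worsening the read-out, and a 4.9-fold lower number from compound 2 to compound 3 (0.69 log units; beyond the scatter) shows the benzyl change recovering it on the methyl-bearing core.

Compound 4 `Cc1cc(S(=O)(=O)/N=C(\N)n2nccc2-c2ccccc2)c(SCc2ccccc2Cl)cc1Cl` is the unmeasured analogue of compound 1: 2-chlorophenyl in place of 3-methylphenyl on a saturated chain carbon bound to a sulfur. Going by the values given here, the one step that bears on this change is a 4.9-fold lower number from compound 2 to compound 3 (0.69 log units; beyond the scatter), a swap of a chlorophenyl for the 3-methylphenyl at the same place, although with 4-chlorophenyl and on a different core. Among the compounds with values here, no measured pair shows a 2-chlorophenyl at this position. A step of similar direction but smaller size is therefore expected for compound 4, as a 1.4-fold lower number from compound 1 to compound 4 (0.16 log units; within the scatter), with wide uncertainty. Compound 4 is estimated at 4500 nM in this assay, in a range from 1500 nM to 13000 nM.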

Compound 4, half-maximal inhibitory concentration: 18000 nM
Beside the measured number, compound 4's estimate is 4.0-fold (0.60 log units) below it; measured number outside the range, above it.
By their numbers in this assay, from the lowest: compounds 1 and 3 (each within the scatter of the next); then compounds 4 and 2 (each within the scatter of the next).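

In this assay, the step of a 2.8-fold higher number from compound 1 to compound 4 (0.44 log units; beyond the scatter) shows that putting a chlorophenyl where the 3-methylphenyl stood does not always lower the number, as it runs in the opposite direction to the step of a 4.9-fold lower number from compound 2 to compound 3 (0.69 log units; beyond the scatter). These two steps differ both in the group that enters, 2-chlorophenyl against 4-chlorophenyl, and in the core that carries it, so together they cannot show which of these differences sets the direction. No measurement at hand gives a cause for the rise from compound 1 to compound 4.

Still open, going by these compounds, is whether 2-chlorophenyl on the core of compound 2 and 4-chlorophenyl on the core of compound 1 would repeat the direction seen with the same group on the other core, a pair of results that would separate the group from the core. Also open, on these data alone, is how this read-out would respond to an unsubstituted phenyl, to an amine or a carboxylic acid on the phenyl ring, or to a longer chain between the sulfur and the ring.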